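A few compounds are considered here, and "the series" means these few. Any claim that something is new, unique, unknown or untested is made for them only; others in the source may bear on it.

Within the data shown here, in a functional assay on MCF7 cells (Homo sapiens) for inhibition, read by sulforhodamine B assay (on this read-out lower numbers stand for stronger inhibition and higher numbers for weaker inhibition), compound 3 `O=C1C=C(Nc2ccc(Br)cc2)C(=O)c2c1nc1n2[C@H]2OC[C@@H](O)[C@H]2OC1` gives 2580 nM, the only actual number so far. Compound 1 `O=C1C(NC2CCCC2)=CC(=O)c2c1nc1n2[C@H]2OC[C@@H](O)[C@H]2OC1` gives > 16000 nM, which is a limit. Compound 2 `Cc1ccc(NC2=CC(=O)c3c(nc4n3[C@H]3OC[C@@H](O)[C@H]3OC4)C2=O)cc1` gives > 4000 nM, also a limit. Compound 4 `O=C1C=C(Nc2ccccc2)C(=O)c2c1nc1n2[C@H]2OC[C@@H](O)[C@H]2OC1` differs from compound 3 by hydrogen in place of bromo on an aromatic carbon, para to a large group. Among the measured compounds shown here, the sole measured step, a step that the two limits leave unreadable from compound 1 to compound 2, has no readable size and changes a different group, so it offers no direct measure for this change. For the measured compounds named here, compound 3 at 2580 nM is the only compound to give a number, and it alone carries bromo, so weaker inhibition is expected on losing it. The expected step is a 2.3-fold higher number from compound 3 to compound 4 (0.37 log units; beyond the scatter). The estimate for compound 4 is 6000 nM, with an expected range of 2500 nM to 16000 nM.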

Compound 4, half-maximal inhibitory concentration: > 4000 nM
Compound 4 was reported as a limit (the forecaster's own chance of this, stated with the estimate: 45%); the middle value does not contradict the limit.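

In this assay, among these compounds, this is the first step with a readable direction, and it concerns the 4-bromophenyl group: hydrogen in place of bromo gives an at least 1.5-fold higher number from compound 3 to compound 4 (0.19 log units; that floor lies within the scatter). Only that floor can be read, so a real loss on removing bromo is possible but not established. The value of compound 4 is a limit, and it is not alone there: the limit of > 4000 nM in this assay, at which 2 of the 4 values shown sit.

Going by these compounds, how far compound 4 lies past its limit stays open. Chloro or methoxy in place of bromo would test whether a measurable number needs bromo specifically or holds for other groups at this place.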